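Dropping the distal phenyl ring on the way to compound 3

A few compounds are considered here, and "the series" means these few. Any claim that something is new, unique, unknown or untested is made for them only; others in the source may bear on it.

Measured so far:
- compound 1, `O=C(CC1c2ccccc2N=C(SCCCCCN2CCCC2)N1c1ccccc1)NCc1ccc(F)cc1`: 664000 nM
- compound 2, `CN(C)CCCCCSC1=Nc2ccccc2C(CC(=O)NCc2ccc(F)cc2)N1c1ccc(-c2ccccc2)cc1`: 6100 nM

In an assay on cells for inhibition of Voltage-dependent T-type calcium channel subunit alpha-1I (Homo sapiens), read by patch clamp (a higher number here means a weaker inhibitor, a lower number a stronger inhibitor), compound 2 gives 6100 nM, the lower of the two numbers recorded, and compound 1 gives 664000 nM, a gap that lies beyond the scatter. The two compounds differ in two places at once, in the amine at the end of the chain and in the ring on the nitrogen of the shared core, so the data do not say which of the two changes carries the gap.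

Compound 3, `CN(C)CCCCCSC1=Nc2ccccc2C(CC(=O)NCc2ccc(F)cc2)N1c1ccccc1`, differs from compound 2 only at the ring on that nitrogen: hydrogen in place of phenyl on an aromatic carbon. Compound 3 thus keeps the amine of compound 2 but shares the phenyl of compound 1. Within the data shown here, with no single-change step measured, the expectation rests on the gap between compound 1 and compound 2 alone. If part of that gap belongs to the ring change, compound 3 is expected to give a higher number than compound 2, by a step of a 9.8-fold higher number from compound 2 to compound 3 (0.99 log units; beyond the scatter). Compound 3 is therefore estimated at 60000 nM in this assay, with a range from 8000 nM to 400000 nM.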

Compound 3, half-maximal inhibitory concentration: "not active" (no number reported)
Nothing numeric was reported for compound 3; no gap can be computed for the estimate.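

Among these compounds, compound 3 is recorded as not active, with no number reported, so no step from compound 2 to compound 3 can be read. The compounds shown leave open how much of the gap between compound 1 and compound 2 belongs to the amine and how much to the 4-phenylphenyl ring. Nothing shown bears on the cause of this result.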